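The source may report more compounds than this note shows. Statements on the series, on what has been measured and on what is new or still open speak of the compounds shown alone.

Compound 2 `COc1cc(-c2nc(SC)nc(NCCCCNc3ccnc4cc(Cl)ccc34)c2C#N)cc(OC)c1OC` stands at the upper end of the two numbers recorded so far: in an ADME assay on L1210 cells (Mus musculus) for inhibition, read by cell counting (a lower number here means a stronger inhibitor, a higher number a weaker inhibitor), compound 2 gives 3800 nM. The nearest point is compound 1 `COc1ccc(-c2nc(SC)nc(NCCCCNc3ccnc4cc(Cl)ccc34)c2C#N)cc1`, which in this assay gives 3200 nM; the step of a 1.2-fold higher number from compound 1 to compound 2 (0.07 log units; within the scatter) lies within the scatter, so the two compounds cannot be ordered against each other. The next compound, compound 3 `CSc1nc(NCCCCNc2ccnc3cc(Cl)ccc23)c(C#N)c(-c2ccc(C)cc2)n1`, carries 4-methylphenyl in place of 3,4,5-trimethoxyphenyl on an aromatic carbon. Going by the values given here, the only measured step that bears on this position is a 1.2-fold higher number from compound 1 to compound 2 (0.07 log units; within the scatter), where exchanging one aryl group at the same place for another left the number essentially unchanged. On that basis, and with no further information on this position, the step in this assay is expected to be a 1.1-fold lower number from compound 2 to compound 3 (0.04 log units; within the scatter), that is, no change beyond the scatter. Compound 3 is therefore estimated at 3500 nM, with a range from 1200 nM to 10000 nM.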

Compound 3, half-maximal inhibitory concentration: 4300 nM
Beside the measured number, compound 3's estimate is 1.2-fold (0.09 log units) below it, and the stated range covers the measured number.
By their numbers in this assay, from the lowest: compounds 1, 2 and 3 (each within the scatter of the next).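

In this assay the new steps read a 1.1-fold higher number from compound 2 to compound 3 (0.05 log units; within the scatter) and a 1.3-fold higher number from compound 1 to compound 3 (0.13 log units; within the scatter) so neither 4-methylphenyl in place of 3,4,5-trimethoxyphenyl nor methyl in place of methoxy can be told from the scatter. The earlier step compared only methoxy-bearing aryl groups, whereas here an aryl group with 0 hydrogen-bond acceptors and 7 heavy atoms replaces one with 3 hydrogen-bond acceptors and 12 heavy atoms, and compound 3 still cannot be ordered against compound 1 or compound 2. Nothing at hand bears on why this position responds in this way.

From the compounds shown here alone, it remains open whether an aryl group carrying an amine or a carboxylic acid, or a longer alkyl chain at this carbon, would give a step beyond the scatter. The compounds shown also leave open what an amine in place of the methylsulfanyl group would do.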